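Aryl variation on the shared core: working notes

This account rests on a few compounds, and the source may have more. Where it says the series, first, only, none or still open, it means among the compounds named here.

Measured so far in an assay (Rattus norvegicus) for inhibition of Fatty-acid amide hydrolase 1 (Homo sapiens); on this read-out higher numbers stand for weaker inhibition and lower numbers for stronger inhibition:
compound 1 `COc1ccccc1-c1cnc(C(=O)CCCCCCc2ccccc2)o1` gives 400 nM
compound 2 `COc1ccc(-c2cnc(C(=O)CCCCCCc3ccccc3)o2)cc1` gives 100 nM
compound 3 `N#Cc1ccc(-c2cnc(C(=O)CCCCCCc3ccccc3)o2)cc1` gives 40 nM

Compound 3 stands lowest of the three numbers; its steps to both others are beyond the scatter, so on this read-out it is the strongest inhibitor of the set. The moves that led there were a 4.0-fold lower number from compound 1 to compound 2 (0.60 log units; beyond the scatter) and a 2.5-fold lower number from compound 2 to compound 3 (0.40 log units; beyond the scatter), which together make a 10-fold lower number from compound 1 to compound 3 (1.00 log units; beyond the scatter).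

Compound 4 `Cc1ccnc(-c2cnc(C(=O)CCCCCCc3ccccc3)o2)c1` is not yet measured. Its change from compound 3 is 4-methylpyridin-2-yl in place of 4-cyanophenyl on an aromatic carbon. Among the measured compounds shown here, none of the measured steps carries exactly this change: no pyridyl ring and no methyl group appears among the three measured compounds. What does bear on it is that the nitrile of compound 3 accounts for the best number through a 2.5-fold lower number from compound 2 to compound 3 (0.40 log units; beyond the scatter), and that moving a substituent from the 2-position to the 4-position of the phenyl gave a 4.0-fold lower number from compound 1 to compound 2 (0.60 log units; beyond the scatter). Compound 4 gives up the nitrile and its aromatic ring carries its one hetero atom and its methyl in a different arrangement. A weaker number than compound 3 is therefore expected, the estimated step being a 3.8-fold higher number from compound 3 to compound 4 (0.57 log units; beyond the scatter), with wide uncertainty. Compound 4 is expected near 150 nM, plausibly between 50 nM and 500 nM.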

Compound 4, inhibition constant: 0.6 nM
The estimate for compound 4 lay 250-fold (2.40 log units) above the measured number; measured number below the stated range.
By their numbers in this assay, from the lowest: compound 4; then compound 3; then compound 2; then compound 1.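

The aromatic carbon next to the ring oxygen of the shared core has a much wider range than the phenyl variants alone showed: in this assay, the widest step among those variants is a 10-fold lower number from compound 1 to compound 3 (1.00 log units; beyond the scatter), whereas 4-methylpyridin-2-yl in place of 4-cyanophenyl gives a 67-fold lower number from compound 3 to compound 4 (1.82 log units; beyond the scatter). The same replacement gives a 170-fold lower number from compound 2 to compound 4 (2.22 log units; beyond the scatter) and a 670-fold lower number from compound 1 to compound 4 (2.82 log units; beyond the scatter), so compound 4 is the strongest inhibitor of the four, and neither the nitrile nor a six-membered aromatic ring of carbon only is needed for the lowest number here. Nothing available on these compounds accounts for the size of this gain.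

This change alters the ring atoms and the substituent together, so the compounds shown do not separate the contribution of the hetero atom from that of the methyl; a pyridine ring without the methyl and a phenyl ring carrying the methyl would divide the step between them. Also open, as far as these compounds go, is how far the new ring tolerates other groups in place of the methyl, such as a nitrile, a methoxy group, an amine or a carboxylic acid.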